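Chloro-to-methyl swap on the hydroxyphenyl ring of compound 1

The compounds below may be only part of what the source reports. "The series", "measured", "known", "first", "only" and "open" are said of these compounds alone.

Measured:
compound 1 `O=C(CC(=O)c1cc(Cl)ccc1O)c1cc2ccccc2s1` — 7.48 ug/mL
compound 2 `Cc1cc(O)c(C(=O)CC(=O)c2cc3ccccc3s2)cc1Cl` — > 100 ug/mL

Going by the values given here, in an ADME assay on THP-1 cells (Homo sapiens) for inhibition, read by MTT assay, with a stated time of 72 h (on this read-out lower numbers stand for stronger inhibition of growth and higher numbers for weaker inhibition of growth), compound 1 gives 7.48 ug/mL, the only numerical value in the set. For compound 2 the assay returns only a limit, > 100 ug/mL. The step of an at least 13-fold higher number from compound 1 to compound 2 (1.12 log units; beyond the scatter) thus rests on a limit of > 100 ug/mL in this assay, at which 1 of the 2 values shown sits, and is large.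

Compound 3 `Cc1ccc(O)c(C(=O)CC(=O)c2cc3ccccc3s2)c1` differs from compound 1 by methyl in place of chloro on an aromatic carbon; the methyl enters at the site the chloro leaves, meta to a large group and para to a hydroxy group. Among the compounds with values here, no measured step covers this exchange; the one step known concerns a methyl added elsewhere on the same ring, and it weakened growth inhibition well beyond the scatter. On that basis a step toward weaker inhibition is expected, of moderate size, a 2.0-fold higher number from compound 1 to compound 3 (0.30 log units; within the scatter). The estimate for compound 3 in this assay is 15 ug/mL, between 5 ug/mL and 60 ug/mL.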

Compound 3, concentration for 50% growth inhibition: > 100 ug/mL
Compound 3: only a limit was reported; the forecaster's own chance of this, stated with the estimate: 25%; at least 6.6-fold (0.82 log units) between middle value and limit.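

In this assay, methyl in place of chloro, at the site para to a hydroxy group, gives an at least 13-fold higher number from compound 1 to compound 3 (1.12 log units; beyond the scatter), so this exchange is not tolerated at this position. Compound 3 gives only a limit, > 100 ug/mL, not a number. Compound 2 keeps the chloro and carries an added methyl on the same ring, so two different single changes to compound 1 now end at the same ceiling, and compound 1 remains the only compound with a number: the limit of > 100 ug/mL in this assay, at which 2 of the 3 values shown sit.

Going by these compounds, how far compound 3 lies past that limit stays unknown, so the sizes of the two steps cannot be ranked. Also open, on these data alone, is whether growth inhibition depends on the chloro itself or is lost only with methyl, a question that hydrogen, fluoro, methoxy or an amine at this position would address.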